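A Chloro-to-Fluoro Swap on the Carbon-Linked Aryl

This account rests on a few compounds, and the source may have more. Where it says the series, first, only, none or still open, it means among the compounds named here.

Measured compounds:
compound 1, `Fc1ccc(C2CC(c3ccccc3)=NN2c2ccc(-c3ccccc3)nn2)cc1`: 8420 nM
compound 2, `Clc1ccc(C2=NN(c3ccc(-c4ccccc4)nn3)C(c3ccc(Cl)cc3)C2)cc1`: 10000 nM

In a functional assay on HepG2 cells (Homo sapiens) for antiproliferative activity, read by MTT assay, with a stated time of 24 h (on this read-out higher numbers stand for weaker inhibition and lower numbers for stronger inhibition), compound 1 gives 8420 nM and compound 2 gives 10000 nM. Compound 2 carries the higher of the two numbers, yet its gap to compound 1 lies within the scatter, so the two are not set apart. Compound 3, `Fc1ccc(C2CC(c3ccc(Cl)cc3)=NN2c2ccc(-c3ccccc3)nn2)cc1`, differs from compound 2 by fluoro in place of chloro on an aromatic carbon, read one bond further out as 4-chlorophenyl to 4-fluorophenyl. Among the measured compounds shown here, no step between measured compounds is known, and the two numbers at hand sit close together, so no step beyond the scatter is expected in either direction. The step from compound 2 to compound 3 is estimated as a 1.1-fold lower number from compound 2 to compound 3 (0.05 log units; within the scatter). Compound 3 is therefore expected near 9000 nM, within 4500 nM to 18000 nM.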

Compound 3, half-maximal inhibitory concentration: 10000 nM
Beside the measured number, compound 3's estimate is 1.1-fold (0.05 log units) below it; the measured number falls inside the stated range.
By their numbers in this assay, from the lowest: compounds 1, 2 and 3 (each within the scatter of the next).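

In this assay, among the compounds shown here, fluoro in place of chloro on an aromatic carbon gives no change at the digits printed from compound 2 to compound 3 (within the scatter) and so provides the first reading at this position, where the two halogens are not set apart. Chloro in place of hydrogen on an aromatic carbon gives a 1.2-fold higher number from compound 1 to compound 3 (0.07 log units; within the scatter) and does not set compound 1 and compound 3 apart either. Going by these compounds, whether an amine, a carboxylic acid or a methoxy group at this position would give a step beyond the scatter stays open. Nothing at hand offers a reason for these numbers.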